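Exchanging One Halogen-Type Substituent for Another on the Phenyl Ring

The compounds below may be only part of what the source reports. "The series", "measured", "known", "first", "only" and "open" are said of these compounds alone.

Compound 1 `CSc1ncc(-c2ccc(S(C)(=O)=O)cc2)n1-c1ccc(F)cc1` was tested in a functional assay on the whole organism (strain Sprague-Dawley) with Rattus norvegicus as the target, read by paw edema, with a stated time of 3 h, at a dose of 50 mg/kg by the oral route (a lower number here means less inhibition, a higher number more inhibition at the dose given (going by the name of the read-out)), where compound 1 gives 40%, the lower of the two numbers seen so far. Compound 2 `CCSc1ncc(-c2ccc(S(C)(=O)=O)cc2)n1-c1ccc(F)cc1`, which carries a methyl in place of a hydrogen on a saturated chain carbon bound to a sulfur, gives 65% in this assay, a rise described as a number 25 percentage points higher from compound 1 to compound 2 (beyond the scatter).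

Compound 3 `CSc1ncc(-c2ccc(S(C)(=O)=O)cc2)n1-c1ccc(Br)cc1` has not been measured. It differs from compound 1 in one spot: bromo in place of fluoro on an aromatic carbon. Within the data shown here, no measured step touches this part of the molecule, since the only step seen alters the chain on the sulfur, so there is no direct guide to the size or direction of the change in this assay. With nothing to point either way, the step from compound 1 is expected to remain within the scatter: a number 5 percentage points higher from compound 1 to compound 3 (within the scatter). Compound 3 is therefore estimated at 45%, with a range from 20% to 70%.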

Compound 3, a percentage reported as inhibition, in the whole organism at one dose (the size of the read-out at that dose, not a potency): 90.7%
Estimate against measurement, compound 3: 45.7 percentage points below; measured number above the stated range.
By their numbers in this assay, from the lowest: compound 1; then compound 2; then compound 3.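

Going from 4-fluorophenyl to 4-bromophenyl in this assay gives a number 50.7 percentage points higher from compound 1 to compound 3 (beyond the scatter), so a single atom exchanged on the aromatic ring is enough to change the read-out markedly. The earlier pair of compounds showed only that the chain on the sulfur matters; this step shows that the ring carbon carrying the halogen is also a place where the response can move, and that the core of compound 1 can give a much higher number without any change to that chain. Nothing available here gives a measured reason for this rise.

On these data alone, it remains open whether chloro or iodo at this ring carbon would fall near fluoro or near bromo, and what a methoxy or an amine would do there. As far as these compounds go, it is also open whether the ethyl chain on the sulfur and the bromo would add up when present in one molecule.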